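Extending the chain on the ring nitrogen of compound 3

The source may report more compounds than this note shows. Statements on the series, on what has been measured and on what is new or still open speak of the compounds shown alone.

Compound 1 `CCCn1c(-c2ccccc2)nc2c(N)ncnc21`: 9280 nM
Compound 2 `CCCn1c(-c2ccccc2)nc2c(NC3CCOC3)ncnc21`: 2810 nM
Compound 3 `Cn1c(-c2ccccc2)nc2c(NC3CCCCC3)ncnc21`: 2370 nM

In an assay on CHO cells for displacement of a labelled ligand from adenosine receptor A3 (Homo sapiens), read by scintillation counting, with a stated time of 3 h (on this read-out lower numbers stand for stronger inhibition and higher numbers for weaker inhibition), compound 3 gives the lowest of the three numbers shown. Its gap to compound 2 lies within the scatter, so the two cannot be ordered; only compound 1 stands clearly apart with a higher number. Going by the values given here, the one measured step, a 3.3-fold lower number from compound 1 to compound 2 (0.52 log units; beyond the scatter), concerns the amine substituent and not the chain on the aromatic nitrogen.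

Compound 4 `CCCn1c(-c2ccccc2)nc2c(NC3CCCCC3)ncnc21` differs from compound 3 by ethyl in place of hydrogen on a saturated chain carbon bound to an aromatic nitrogen, which read one bond further out is methyl to propyl. Among the compounds with values here, compounds 1 and 2 already carry the propyl chain, but they also differ from compound 3 at the amine, so no measured step isolates this change. Nothing in the data supports a shift beyond the scatter in this assay in either direction.

Compound 4 is therefore expected near 2000 nM, within 800 nM to 5000 nM, a step of a 1.2-fold lower number from compound 3 to compound 4 (0.07 log units; within the scatter) that is estimated to stay within the scatter.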

Compound 4, inhibition constant: 2360 nM
Compound 4: the middle estimate sits 1.2-fold (0.07 log units) below what was measured; the measured number falls inside the stated range.
By their numbers in this assay, from the lowest: compounds 4, 3 and 2 (each within the scatter of the next); then compound 1.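

In this assay, the first step measured at this position, methyl to propyl with cyclohexyl held on the amine (a 1.0-fold lower number from compound 3 to compound 4 (0.00 log units; within the scatter)), shows that the two numbers cannot be told apart. Compound 4 also allows the amine substituent to be read with the propyl chain held: cyclohexyl in place of oxolan-3-yl (a 1.2-fold lower number from compound 2 to compound 4 (0.08 log units; within the scatter)) cannot be told apart either, whereas cyclohexyl in place of hydrogen (a 3.9-fold lower number from compound 1 to compound 4 (0.59 log units; beyond the scatter)) stands clear of the scatter. No evidence is at hand on why these steps come out as they do.

Going by these compounds, the chain step is read with cyclohexyl alone, so its size with another amine substituent remains open. Also open, on these data alone, is how a longer chain, such as butyl, or a chain ending in a carboxylic acid, would read on the aromatic nitrogen.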